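The source may report more compounds than this note shows. Statements on the series, on what has been measured and on what is new or still open speak of the compounds shown alone.

In a functional assay on HL-60 cells (Homo sapiens) for cytotoxicity, read by MTT assay, with a stated time of 3 days (on this read-out higher numbers stand for weaker inhibition and lower numbers for stronger inhibition), compound 1 `N#Cc1c(Cl)nc(SCc2nc3ccccc3[nH]2)nc1-c1ccccc1` gives 4.46 nM, compound 2 `N#Cc1c(Nc2ccccc2)nc(SCc2nc3ccccc3[nH]2)nc1-c1ccccc1` gives 4.46 nM, and compound 3 `N#Cc1c(Nc2ccccn2)nc(SCc2nc3ccccc3[nH]2)nc1-c1ccccc1` gives 20 nM, the highest number of the three. Compound 4 `N#Cc1c(NC(N)=O)nc(SCc2nc3ccccc3[nH]2)nc1-c1ccccc1` has carbamoyl in place of pyridin-2-yl on a nitrogen on an aromatic ring. Among the measured compounds shown here, two measured steps bear on this change. Anilino in place of chloro gave no change at the digits printed from compound 1 to compound 2 (within the scatter), while pyridin-2-yl in place of phenyl on that nitrogen gave a 4.5-fold higher number from compound 2 to compound 3 (0.65 log units; beyond the scatter). For the measured compounds named here, no compound with a carbamoyl group has been measured, so only a modest step is expected in this assay, more likely toward lower numbers than higher ones. The expected change is a 2.0-fold lower number from compound 3 to compound 4 (0.30 log units; within the scatter). For compound 4, the estimate is 10 nM, with an expected range from 3 nM to 40 nM.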

Compound 4, half-maximal inhibitory concentration: 2.9 nM
The estimate for compound 4 lay 3.4-fold (0.54 log units) above the measured number, and the stated range ends above it.
By their numbers in this assay, from the lowest: compounds 4, 1 and 2 (each within the scatter of the next); then compound 3.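

In this assay, carbamoyl in place of pyridin-2-yl on a nitrogen on an aromatic ring gives a 6.9-fold lower number from compound 3 to compound 4 (0.84 log units; beyond the scatter), so the higher number of compound 3 does not carry over to this ringless group. The other steps, a 1.5-fold lower number from compound 2 to compound 4 (0.19 log units; within the scatter) and a 1.5-fold lower number from compound 1 to compound 4 (0.19 log units; within the scatter), both lie within the scatter, leaving ureido, anilino and chloro indistinguishable here, with only (pyridin-2-yl)amino standing apart. Nothing at hand gives a reason for this. On these data alone, whether a plain amino group or an acetamido group would stay level with compound 4 remains open.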